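Compound 1 and the piperidin-1-yl swap

The source may report more compounds than this note shows. Statements on the series, on what has been measured and on what is new or still open speak of the compounds shown alone.

- compound 1 `O=C(/C=C/c1ccc([N+](=O)[O-])o1)c1ccc(I)cc1` with 49500 nM
- compound 2 `O=C(/C=C/c1ccc([N+](=O)[O-])s1)c1ccc(-n2ccnc2)cc1` with 23400 nM

Both values come from an ADME assay on THP-1 cells (Homo sapiens) for cytotoxicity, read by resazurin assay, with a stated time of 72 h (a higher number here means that more compound is tolerated, a lower number that less compound is tolerated), and, of the two, compound 1 stands higher at 49500 nM while compound 2 stands lower at 23400 nM by more than the usual scatter. For the measured compounds named here, these two compounds differ in more than one place, so they offer no single-change step for sizing the next move.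

The move to compound 3 `O=C(/C=C/c1ccc([N+](=O)[O-])o1)c1ccc(N2CCCCC2)cc1` is piperidin-1-yl in place of iodo on an aromatic carbon and it puts piperidin-1-yl in place of iodo on an aromatic carbon, para to a large group. Going by the values given here, no measured pair shows what this swap does in this assay and any forecast is therefore loose. Since compound 1 at 49500 nM holds the higher of the two values, a modest move to a lower number is expected rather than a further rise. The expected change is a 2.0-fold lower number from compound 1 to compound 3 (0.30 log units; within the scatter) and it may prove hard to separate from the scatter. For compound 3 the estimated value is 25000 nM with an expected range from 8000 nM to 70000 nM in this measurement.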

Compound 3, half-maximal cytotoxic concentration: > 50000 nM
Compound 3: only a limit was reported (the forecaster's own chance of this, stated with the estimate: 10%); middle value at least 2.0-fold (0.30 log units) from the limit.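

In this assay compound 3 carries a limit and not a number, > 50000 nM. Piperidin-1-yl in place of iodo on an aromatic carbon, para to a large group, gives a number no lower from compound 1 to compound 3 (the limit leaves the size open), so this position accepts one six-membered non-aromatic ring with 1 hetero atom, and 6 heavy atoms in place of 1, with no fall in the number. How far the number moves cannot be taken from this reading: the limit of > 50000 nM in this assay, at which 1 of the 3 values shown sits.

Going by these compounds, the size of the step remains open, so the result cannot tell whether piperidin-1-yl differs from iodo by more than the usual scatter or by nothing at all. Also open, on these data alone, is whether another amine at this place, such as morpholin-4-yl or dimethylamino, or a carboxylic acid, would leave the number just as unmoved, and whether piperidin-1-yl would act in the same way on the core of compound 2.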